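Swapping the aryl group on the imine carbon of a benzofuran core

A few compounds are considered here, and "the series" means these few. Any claim that something is new, unique, unknown or untested is made for them only; others in the source may bear on it.

Compound 1 `CCCCc1oc2ccc(/N=C/c3ccc(Cl)cc3)cc2c1C(=O)c1ccc(OC)cc1` gives 75.9 ug/mL.
Compound 2 `CCCCc1oc2ccc(/N=C/c3ccccc3O)cc2c1C(=O)c1ccc(OC)cc1` gives 99.4 ug/mL.

These two compounds were tested in a functional assay, with a stated time of 30 min; on this read-out higher numbers stand for weaker inhibition and lower numbers for stronger inhibition. Compound 2 gives the highest of the two numbers, and its nearest neighbour, compound 1, lies within the scatter of it. Going by the values given here, the only measured step, a 1.3-fold higher number from compound 1 to compound 2 (0.12 log units; within the scatter), therefore shows no change beyond the scatter when one aryl group on the imine carbon is exchanged for another.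

Compound 3 `CCCCc1oc2ccc(/N=C/c3ccc(CC)cc3)cc2c1C(=O)c1ccc(OC)cc1` has not yet been measured. It differs from compound 2 in one place: 4-ethylphenyl in place of 2-hydroxyphenyl on a carbon with a double bond to nitrogen. Among the compounds with values here, the one step that bears on this change, a 1.3-fold higher number from compound 1 to compound 2 (0.12 log units; within the scatter), was within the scatter, so the expected step of a 1.2-fold lower number from compound 2 to compound 3 (0.07 log units; within the scatter) in this assay is likewise no change beyond the scatter, in no particular direction. The estimate for compound 3 is 85 ug/mL, expected to fall between 40 ug/mL and 180 ug/mL.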

Compound 3, half-maximal inhibitory concentration: 3.69 ug/mL
The estimate for compound 3 lay 23-fold (1.36 log units) above the measured number, and the stated range ends above it.
By their numbers in this assay, from the lowest: compound 3; then compounds 1 and 2 (each within the scatter of the next).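

In this assay the aryl group on the carbon with a double bond to nitrogen turns out to matter a great deal, which the earlier pair did not reveal: 4-ethylphenyl in place of 2-hydroxyphenyl gives a 27-fold lower number from compound 2 to compound 3 (1.43 log units; beyond the scatter) and so much stronger inhibition. Ethyl in place of chloro on an aromatic carbon gives a 21-fold lower number from compound 1 to compound 3 (1.31 log units; beyond the scatter) even though neither compound carries a hydroxyl group, so in this pair exchanging that one substituent is enough to produce a large step. Nothing available here explains why ethyl stands apart from the other groups.

As far as these compounds go, whether this holds only for ethyl remains open, since methyl, propyl or a longer chain in its place could give a different number. An amine or a methoxy group in the same place would show whether groups not built only of carbon and hydrogen can give such a step.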